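This account rests on a few compounds, and the source may have more. Where it says the series, first, only, none or still open, it means among the compounds named here.

Compound 3 `CC1=C(C(=O)Nc2ccc([N+](=O)[O-])cc2)C(c2cccc([N+](=O)[O-])c2)N=C(SCc2ccccc2)N1` stands second highest of the three numbers in a functional assay on the whole organism (artery, strain albino) with Rattus norvegicus as the target, with a stated time of 240 min, at a dose of 10 mg/kg by the oral route; on this read-out higher numbers stand for more inhibition at the one dose given (going by the name of the read-out) and lower numbers for less inhibition: compound 3 gives 21%, compound 2 `CC1=C(C(=O)Nc2ccc([N+](=O)[O-])cc2)C(c2ccc(Br)cc2)N=C(SCc2ccccc2)N1` gives 27.7%, and compound 1 `COc1ccc(C2N=C(SCc3ccccc3)NC(C)=C2C(=O)Nc2ccc(F)cc2)cc1OC` gives 11.8%. Both gaps from compound 3 lie within the scatter, so no order among the three can be claimed. Compound 4 `CC1=C(C(=O)Nc2ccc([N+](=O)[O-])cc2)C(c2cccc([N+](=O)[O-])c2)N=C(SCc2ccc(F)cc2)N1` differs from compound 3 by fluoro in place of hydrogen on an aromatic carbon. For the measured compounds named here, the only measured step, a number 6.7 percentage points lower from compound 2 to compound 3 (within the scatter), changed the group on the saturated ring carbon rather than the benzylsulfanyl group, so no measured step bears directly on this change; it shows only that altering one part left the number within the scatter. A step of about no change at the digits printed from compound 3 to compound 4 (within the scatter) is therefore expected, nothing beyond the scatter. Compound 4 is estimated at 21%, between 8% and 36%.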

Compound 4, a percentage reported as inhibition, in the whole organism at one dose (the size of the read-out at that dose, not a potency): 22.6%
For compound 4 the middle estimate is 1.6 percentage points below the measured one; low and high end bracket the measured number.
By their numbers in this assay, from the lowest: compounds 1, 3, 4 and 2 (each within the scatter of the next, the first and the last beyond it).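

Going from benzylsulfanyl to (4-fluorobenzyl)sulfanyl in this assay gives a number 1.6 percentage points higher from compound 3 to compound 4 (within the scatter) and is the first measured change on this group. At this place on the aromatic ring, then, a single fluoro leaves the read-out indistinguishable from that of the hydrogen compound. No measurement shown offers an explanation for this result. Still open, going by these compounds, is whether an amine or a carboxylic acid at the same ring carbon would also stay within the scatter. Also open, on these data alone, is whether a longer chain in place of the benzyl group would do so.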